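The source may hold more compounds than are shown below. What is called first, only, known or untested is meant among the compounds shown, and "the series" means these compounds.

Compound 3, `FC(F)(F)c1ccc(COc2ccc(Nc3ncnc4cc5c(cc34)OCCOCCO5)cc2)cc1`, is tested in a functional assay on SH-SY5Y cells (Homo sapiens) for antiproliferative activity, read by MTT assay, with a stated time of 72 h (a higher number here means a weaker inhibitor, a lower number a stronger inhibitor), and gives 30400 nM. Compound 1, `O=[N+]([O-])c1ccc(COc2ccc(Nc3ncnc4cc5c(cc34)OCCOCCO5)cc2)cc1`, gives 55200 nM in this assay and differs from compound 3 by a single change, (nitro in place of trifluoromethyl on an aromatic carbon), and from compound 3 to compound 1 the measured step is a 1.8-fold higher number from compound 3 to compound 1 (0.26 log units; within the scatter). Compound 2, `FC(F)(F)c1ccc(COc2ccccc2Nc2ncnc3cc4c(cc23)OCCOCCOCCO4)cc1`, has a different core; how the core of compound 2 and the core of compound 3 differ is not broken down here. In this assay compound 2 gives only a limit, > 100000 nM, and no number. One of the three measured values sits at the limit of > 100000 nM in this assay, at which 1 of the 3 values shown sits. Compound 4, `O=[N+]([O-])c1ccc(COc2ccccc2Nc2ncnc3cc4c(cc23)OCCOCCOCCO4)cc1`, has not yet been measured; it stands to compound 2 as compound 1 stands to compound 3, carrying (nitro in place of trifluoromethyl on an aromatic carbon), and the place of the change reads the same word for word, so it is the same change. Going by the values given here, the one earlier step, a 1.8-fold higher number from compound 3 to compound 1 (0.26 log units; within the scatter), is the only guide to it. On that basis the move to compound 4 is expected to be a step that the limit leaves unreadable from compound 2 to compound 4. Compound 4 is therefore estimated at 150000 nM, between 60000 nM and 400000 nM, with a real chance that only a limit is reported again.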

Compound 4, half-maximal inhibitory concentration: 75500 nM
The estimate for compound 4 lay 2.0-fold (0.30 log units) above the measured number; low and high end bracket the measured number.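

Compound 2 gives > 100000 nM in this assay, and that is a limit of the assay, not a number. The swap of trifluoromethyl for nitro on this core can therefore be read only as an at least 1.3-fold lower number from compound 2 to compound 4 (0.12 log units; that floor lies within the scatter). This gives no proof that the change carries over from one core to the other in the same way, and no proof that it behaves differently on the two cores: the same change on two cores in this assay, a 1.8-fold higher number (0.26 log units; within the scatter) from compound 3 to compound 1 and an at least 1.3-fold lower number (0.12 log units; that floor lies within the scatter) from compound 2 to compound 4; the limit leaves it open whether they differ

The compounds shown leave open how other groups in the same place on the benzyl ring's carbon, such as a nitrile, an amine or a carboxylic acid, would read in this assay on either core. Whether nitro and trifluoromethyl would stay as close to each other on any further core also remains an open question, since the series shown here offers this change on two cores only, and one of those two steps rests on a limit.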